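Chloro for hydrogen on two related cores

This account rests on a few compounds, and the source may have more. Where it says the series, first, only, none or still open, it means among the compounds named here.

Compound 1 `ClCc1cccc(Cn2cnc3c(Cl)ncnc32)c1` and compound 2 `ClCc1cccc(Cn2cnc3c(Cl)nc(Cl)nc32)c1` share one core; in a functional assay on HCC 2998 cells (Homo sapiens) for cytotoxicity, read by sulforhodamine B assay, with a stated time of 48 h (a higher number here means that more compound is tolerated, a lower number that less compound is tolerated), compound 1 gives 5490 nM and compound 2 gives 6160 nM. The change between them is chloro in place of hydrogen on an aromatic carbon and the step is a 1.1-fold higher number from compound 1 to compound 2 (0.05 log units; within the scatter). Compound 3 `ClCc1ccccc1Cn1cnc2ncnc(Cl)c21` has the same atoms joined differently; the difference between the two cores is not broken down here. In this assay compound 3 gives 7940 nM, within the scatter of both compound 1 and compound 2. Compound 4 `ClCc1ccccc1Cn1cnc2nc(Cl)nc(Cl)c21` differs from compound 3 by chloro in place of hydrogen on an aromatic carbon, the same change as from compound 1 to compound 2. Within the data shown here, only one matching step is available, and because a 1.1-fold higher number from compound 1 to compound 2 (0.05 log units; within the scatter) stayed within the scatter, the expected step is a 1.1-fold higher number from compound 3 to compound 4 (0.03 log units; within the scatter). Compound 4 is therefore estimated at 8500 nM, between 5000 nM and 15000 nM.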

Compound 4, concentration lethal to 50% of the cells: 66100 nM
Compound 4: middle estimate off by 7.8-fold (0.89 log units), on the low side; measured number outside the range, above it.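

Chloro in place of hydrogen on an aromatic carbon gives an 8.3-fold higher number from compound 3 to compound 4 (0.92 log units; beyond the scatter) in this assay. The size of this step does not carry from one core to the other in this series: the same change on two cores in this assay, a 1.1-fold higher number (0.05 log units; within the scatter) from compound 1 to compound 2 and an 8.3-fold higher number (0.92 log units; beyond the scatter) from compound 3 to compound 4, 7.4-fold (0.87 log units) apart, beyond the scatter of two such steps

Among these compounds, with one pair on each core, this shows only that the same change gave steps of different size on these two cores; it does not show what in the cores sets the gap, or how the change would behave on any further core.

Still open, on these data alone, is whether an amine, a methoxy group or a longer chain on the same ring carbon would give a step like that on the core of compound 1 or like that on the core of compound 3.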